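This account rests on a few compounds, and the source may have more. Where it says the series, first, only, none or still open, it means among the compounds named here.

Measured so far:
- compound 3, `CCCCCc1c(C(C)C)nc(C(C)C)c(CO)c1-c1ccc(O)cc1`, in an assay on CHO cells for inhibition of Glucagon receptor (Homo sapiens), tested at 20 uM (a higher number here means more inhibition at the concentration tested (going by the name of the read-out), a lower number less inhibition), gives 24%
- compound 1, `CCCCCc1c(C(C)C)nc(C(C)C)c(CO)c1-c1ccccc1OC`, gives 27%
- compound 2, `CCCCCc1c(C(C)C)nc(C(C)C)c(CO)c1-c1ccc(-c2ccccc2)cc1`, gives 2%

Compound 3 holds the second highest of the three numbers. Its nearest neighbour is compound 1: a number 3 percentage points lower from compound 1 to compound 3 (within the scatter), a step within the scatter. Its furthest is compound 2: a number 22 percentage points higher from compound 2 to compound 3 (beyond the scatter), a modest step beyond the scatter.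

Compound 4, `CCCCCc1c(C(C)C)nc(C(C)C)c(CO)c1-c1ccc(OC)cc1`, differs from compound 3 by methyl in place of hydrogen on an oxygen on an aromatic ring. Within the data shown here, no measured step makes this change. The closest point of comparison is compound 1, which carries a methoxy group at another place and whose value sits within the scatter of compound 3. The step of a number 2 percentage points lower from compound 3 to compound 4 (within the scatter) is therefore expected to stay within the scatter, with no direction favoured. Compound 4 is estimated at 22%, range 5% to 38%.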

Compound 4, a percentage reported as inhibition, at one concentration (the size of the read-out at that concentration, not a potency): 37%
Estimate against measurement, compound 4: 15 percentage points below, within the range that was stated.
By their numbers in this assay, from the lowest: compound 2; then compounds 3, 1 and 4 (each within the scatter of the next, the first and the last beyond it).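

Methyl on the oxygen of the 4-hydroxyphenyl group does not cost inhibition in this assay and instead gives a modest gain (a number 13 percentage points higher from compound 3 to compound 4 (beyond the scatter)), so the hydroxy hydrogen is not needed for the read-out. Against the phenyl-bearing compound the methoxy group gives a large gain (a number 35 percentage points higher from compound 2 to compound 4 (beyond the scatter)), while moving methoxy around the ring gives no readable change (a number 10 percentage points higher from compound 1 to compound 4 (within the scatter)). No measurement at hand explains these steps.

On these data alone, whether a longer chain on that oxygen, such as ethoxy, would hold the number remains open. So does the effect of an amine in the same place.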